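The source may hold more compounds than are shown below. What is called first, only, known or untested is meant among the compounds shown, and "the series" means these compounds.

Of the compounds shown here, three sharing one core have been measured in a functional assay on MDA-MB-435 cells (Homo sapiens) for inhibition, read by sulforhodamine B assay, with a stated time of 48 h; on this read-out higher numbers stand for weaker inhibition of growth and lower numbers for stronger inhibition of growth. Compound 1 `N#C/C(=C\c1c(-c2ccccc2)[nH]c2ccccc12)C(=O)c1ccccc1` gives 370 nM. Compound 2 `COc1ccc2[nH]c(-c3ccccc3)c(C=C(C#N)C#N)c2c1` gives 607 nM, and compound 3 `COc1ccc(-c2[nH]c3ccc(OC)cc3c2C=C(C#N)C#N)cc1` gives 122 nM. Among the measured compounds shown here, the only one-place step among the measured compounds is a 5.0-fold lower number from compound 2 to compound 3 (0.70 log units; beyond the scatter). Compound 1 stands second highest of the three numbers: its gap to compound 2 lies within the scatter, so those two cannot be put in order, while compound 3 sits beyond the scatter below it.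

Compound 4 `N#C/C(=C\c1c(-c2ccccc2)[nH]c2ccccc12)S(=O)(=O)c1ccccc1` has not yet been measured. It differs from compound 1 in one place: phenylsulfonyl in place of benzoyl on a double-bonded chain carbon bound to a double-bonded chain carbon and a triple-bonded carbon. For the measured compounds named here, no measured step touches this part of the structure; the one step known, that from compound 2 to compound 3, concerns a methoxy group on an aromatic carbon and says nothing about the group carried on the chain carbon. The expectation for compound 4 therefore rests on compound 1 alone and must be wide. The estimate is that compound 4 gives 500 nM, with a range from 150 nM to 1700 nM. The expected change, a 1.4-fold higher number from compound 1 to compound 4 (0.13 log units; within the scatter), is estimated to remain within the scatter of compound 1.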

Compound 4, concentration for 50% growth inhibition: 288 nM
For compound 4 the middle estimate is 1.7-fold (0.24 log units) above the measured one, and the stated range covers the measured number.
By their numbers in this assay, from the lowest: compound 3; then compounds 4, 1 and 2 (each within the scatter of the next, the first and the last beyond it).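

In this assay the exchange of benzoyl for phenylsulfonyl on the chain carbon gives a 1.3-fold lower number from compound 1 to compound 4 (0.11 log units; within the scatter) and so leaves the two compounds impossible to put in order. Among the compounds shown here, this is the first measured exchange at this position, and it holds although the entering group differs from the leaving one in more than a simple swap of atoms: heavy atoms go from 8 to 9, hydrogen-bond acceptors from 1 to 2, and double bonds outside aromatic rings from 1 to 2, while both groups keep one six-membered aromatic ring of carbon only. Nothing in the available data speaks to why these two compounds read alike.

Both groups carry that aromatic ring, so the compounds shown leave open how the number would respond to a group on this carbon without such a ring, for example a methyl ester, a carboxylic acid or a simple amide. They also leave open whether the methoxy step seen between compound 2 and compound 3 would carry over to a compound holding phenylsulfonyl at this position.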